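Fluoro for hydrogen on the benzamide of compound 2

This account rests on a few compounds, and the source may have more. Where it says the series, first, only, none or still open, it means among the compounds named here.

Measured compounds:
compound 1 `Cc1cc(C)c(CN2CCc3c(Cl)cc(-c4cn[nH]c4C)c(Cl)c3C2=O)c(=O)[nH]1` — 3.1
compound 2 `COc1cccc(C(=O)NCc2c(C)cc(C)[nH]c2=O)c1` — 1.7
compound 3 `Cc1cc(C)c(CN2CCc3c(Cl)cc(-c4cn[nH]c4)c(Cl)c3C2=O)c(=O)[nH]1` — 3

In a physicochemical assay for lipophilicity, at pH 7.4 (on this read-out lower numbers stand for lower lipophilicity and higher numbers for higher lipophilicity), compound 2 stands lowest of the three; both compound 3 and compound 1 lie above it beyond the scatter, and those two sit within the scatter of each other. Compound 4 `COc1cccc(C(=O)NCc2c(C)cc(C)[nH]c2=O)c1F` is not yet measured. It differs from compound 2 by fluoro in place of hydrogen on an aromatic carbon. Among the measured compounds shown here, the only measured step, a number 0.10 log units lower from compound 1 to compound 3 (within the scatter), concerns a methyl on a different core and does not bear on a fluoro for hydrogen exchange, so no direct precedent exists in this set. A small step is expected, a number 0.20 log units higher from compound 2 to compound 4 (within the scatter), upward at most modestly and possibly within the scatter. Compound 4 is therefore estimated at 1.9, ranging from 1.6 to 2.3.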

Compound 4, distribution coefficient: 1.4
Estimate against measurement, compound 4: 0.50 log units above; measured number outside the range, below it.
By their numbers in this assay, from the lowest: compounds 4 and 2 (each within the scatter of the next); then compounds 3 and 1 (each within the scatter of the next).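

In this assay, fluoro in place of hydrogen on this aromatic carbon, ortho to a large group and ortho to a methoxy group, gives a number 0.30 log units lower from compound 2 to compound 4 (within the scatter), so the read-out does not separate the two compounds at this position. Among the compounds shown here, this is the first exchange read on this part of compound 2, as the only earlier step, a number 0.10 log units lower from compound 1 to compound 3 (within the scatter), lies on a different core. Nothing at hand bears on a cause for this result. On these data alone, whether an amine or a carboxylic acid on the same carbon would separate from compound 2 stays open. As far as these compounds go, whether fluoro at other carbons of this ring would read the same also stays open.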